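One Swap, Measured Once, Expected Again

The source may hold more compounds than are shown below. What is called first, only, known or untested is meant among the compounds shown, and "the series" means these compounds.

Compound 1 `Fc1ccc(Cc2ccc3c(NCCCNCc4ccco4)ccnc3c2)c(Cl)c1`, compound 2 `c1coc(CNCCCNc2ccnc3cc(-c4cccc5ccccc45)ccc23)c1` and compound 3 `COc1cccc(CNCCCNc2ccnc3cc(Cc4ccc(F)cc4Cl)ccc23)c1O` share a core and were tested in an ADME assay on HepG2 cells (Homo sapiens) for cytotoxicity, read by luminescence, CellTiter-Glo and ATP content, with a stated time of 72 h; a higher number here means that more compound is needed for the effect, a lower number that less compound is needed. In that test compound 1 gives 5730 nM, compound 2 gives 5600 nM and compound 3 gives 2350 nM. The change naphthalen-1-yl in place of 2-chloro-4-fluorobenzyl on an aromatic carbon made a step of a 1.0-fold lower number from compound 1 to compound 2 (0.01 log units; within the scatter). The change 2-hydroxy-3-methoxyphenyl in place of furan-2-yl on a saturated chain carbon bound to an amine nitrogen made a step of a 2.4-fold lower number from compound 1 to compound 3 (0.39 log units; beyond the scatter), leaving compound 3 with the lowest number of the three. Compound 4 `COc1cccc(CNCCCNc2ccnc3cc(-c4cccc5ccccc45)ccc23)c1O` has not yet been measured; it differs from compound 3 by naphthalen-1-yl in place of 2-chloro-4-fluorobenzyl on an aromatic carbon, the same change, at the same place, that turned compound 1 into compound 2. Because that earlier step a 1.0-fold lower number from compound 1 to compound 2 (0.01 log units; within the scatter) stayed within the scatter, the step of a 1.0-fold lower number from compound 3 to compound 4 (0.01 log units; within the scatter) is expected to be small as well. Compound 4 is therefore estimated to give 2300 nM, between 1200 nM and 4500 nM.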

Compound 4, half-maximal effective concentration: 2520 nM
The estimate for compound 4 lay 1.1-fold (0.04 log units) below the measured number; the range from low to high includes it.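

In this assay, naphthalen-1-yl in place of 2-chloro-4-fluorobenzyl again made no step beyond the scatter, a 1.1-fold higher number from compound 3 to compound 4 (0.03 log units; within the scatter), matching what it did on the first core: the same change on two cores in this assay, a 1.0-fold lower number (0.01 log units; within the scatter) from compound 1 to compound 2 and a 1.1-fold higher number (0.03 log units; within the scatter) from compound 3 to compound 4, 1.1-fold (0.04 log units) apart, within the scatter of two such steps The other change, 2-hydroxy-3-methoxyphenyl in place of furan-2-yl, also repeated itself, with a 2.2-fold lower number from compound 2 to compound 4 (0.35 log units; beyond the scatter): the same change on two cores in this assay, a 2.4-fold lower number (0.39 log units; beyond the scatter) from compound 1 to compound 3 and a 2.2-fold lower number (0.35 log units; beyond the scatter) from compound 2 to compound 4, 1.1-fold (0.04 log units) apart, within the scatter of two such steps Across these four compounds, each change carried over from one core to the other, but two pairs in one cell assay do not show that this would hold for other groups or explain why it happens.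

As far as these compounds go, it remains open whether a carboxylic acid or an amine on the same aromatic carbon would carry over as consistently. The same question applies to a longer chain in place of the saturated chain bearing the amine nitrogen.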